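The compounds below may be only part of what the source reports. "The series", "measured", "known", "first", "only" and "open" are said of these compounds alone.

In a functional assay on HL-60 cells (Homo sapiens) for cytotoxicity, read by WST assay, with a stated time of 48 h (a higher number here means that more compound is needed for the effect, a lower number that less compound is needed), compound 3 (`CCCCCCCOc1cccc(C[C@H]2C(=O)OC[C@@H]2Cc2ccccc2)c1`) gives 81000 nM and compound 2 (`COCOc1cccc(C[C@H]2C(=O)OC[C@@H]2Cc2ccccc2)c1`) gives 80000 nM, the two level with each other (a 1.0-fold higher number from compound 2 to compound 3 (0.01 log units; within the scatter)). Compound 1 (`O=C1OC[C@H](Cc2ccccc2)[C@H]1Cc1cccc(OC(F)(F)F)c1`) lies apart at 34000 nM (a 2.4-fold higher number from compound 1 to compound 3 (0.38 log units; beyond the scatter); also a 2.4-fold higher number from compound 1 to compound 2 (0.37 log units; beyond the scatter)). Compound 4 (`O=C1OC[C@H](Cc2ccccc2)[C@H]1Cc1cccc(F)c1`) carries fluoro in place of heptyloxy on an aromatic carbon. The measured steps only exchange groups on an oxygen on an aromatic ring, so they bear on this change indirectly, and none removes that oxygen. Those steps stayed modest, which suggests that no step beyond the scatter should be expected in this assay, and the estimated change is small (a 1.6-fold lower number from compound 3 to compound 4 (0.21 log units; within the scatter)). Compound 4 is expected at 50000 nM (estimated range 20000 nM to 100000 nM).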

Compound 4, half-maximal effective concentration: 75000 nM
The estimate for compound 4 lay 1.5-fold (0.18 log units) below the measured number; low and high end bracket the measured number.
By their numbers in this assay, from the lowest: compound 1; then compounds 4, 2 and 3 (each within the scatter of the next).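

In this assay, fluoro on this aromatic carbon, with no oxygen there at all, stands level with heptyloxy (a 1.1-fold lower number from compound 3 to compound 4 (0.03 log units; within the scatter)) and with methoxymethoxy (a 1.1-fold lower number from compound 2 to compound 4 (0.03 log units; within the scatter)), so that oxygen is not needed to reach this level. Only trifluoromethoxy stands apart from fluoro (a 2.2-fold higher number from compound 1 to compound 4 (0.34 log units; beyond the scatter)), which leaves it alone among these groups. Nothing at hand gives a reason for that gap. From the compounds shown here alone, whether an amine or a carboxylic acid on this aromatic carbon would move the number stays open.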